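This account rests on a few compounds, and the source may have more. Where it says the series, first, only, none or still open, it means among the compounds named here.

In an assay on cell membranes for binding affinity to metabotropic glutamate receptor 5 (Rattus norvegicus) (on this read-out higher numbers stand for weaker inhibition and lower numbers for stronger inhibition), three compounds have been measured so far. Compound 1 `N#Cc1cc(C#N)cc(-n2nnc(-c3ccccn3)n2)c1` gives 18 nM, compound 2 `COc1cc(C#N)cc(-n2nnc(-c3ccccn3)n2)c1` gives 6 nM, and compound 3 `N#Cc1cc(N)cc(-n2nnc(-c3ccccn3)n2)c1` gives 95 nM. Compound 2 stands lowest of the three: the step of a 3.0-fold lower number from compound 1 to compound 2 (0.48 log units; beyond the scatter) separates it from compound 1, and the step of a 16-fold higher number from compound 2 to compound 3 (1.20 log units; beyond the scatter) separates it from compound 3, which in turn lies beyond compound 1 by a 5.3-fold higher number from compound 1 to compound 3 (0.72 log units; beyond the scatter). All three share the same core and differ only in the group carried on one aromatic carbon.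

Compound 4 `N#Cc1cc(OCC2CC2)cc(-n2nnc(-c3ccccn3)n2)c1` keeps the oxygen on the aromatic ring that compound 2 carries and grows the chain on it: cyclopropyl in place of hydrogen on a saturated chain carbon bound to an oxygen on an aromatic ring. Going by the values given here, none of the measured steps concerns such a lengthening; each of them exchanged the whole group on the aromatic carbon, and those exchanges shifted this assay by modest to large amounts in both directions, so the position clearly matters. Among the compounds with values here, a chain is grown here rather than a group exchanged, and no measured step shows such a change. The step expected is a 1.7-fold higher number from compound 2 to compound 4 (0.22 log units; within the scatter), with the direction uncertain. Compound 4 is therefore estimated to give about 10 nM in this assay, within a range from 3 nM to 35 nM.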

Compound 4, inhibition constant: 271 nM
The estimate for compound 4 lay 27-fold (1.43 log units) below the measured number; measured number above the stated range.
By their numbers in this assay, from the lowest: compound 2; then compound 1; then compound 3; then compound 4.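

In this assay, keeping the oxygen on the aromatic ring does not by itself preserve strong binding: the change from methoxy to cyclopropylmethoxy produces a 45-fold higher number from compound 2 to compound 4 (1.65 log units; beyond the scatter) and is larger than any earlier step at this position, so what is attached beyond the oxygen matters a great deal. Cyclopropylmethoxy also compares poorly with the other two groups, giving a 15-fold higher number from compound 1 to compound 4 (1.18 log units; beyond the scatter) and a 2.9-fold higher number from compound 3 to compound 4 (0.46 log units; beyond the scatter) so that compound 4 is the weakest inhibitor of the four, with even the amino group of compound 3 doing better. No available measurement bears on what lies behind this loss.

The compounds shown leave open whether the loss comes from the longer chain as such or from the cyclopropyl ring, a question that an ethoxy or a propoxy group at the same position could help to settle. They also leave open how steeply the number rises as the chain grows from methoxy, and whether a group such as a hydroxyl at the end of a longer chain would behave any differently.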